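Urea arm in place of the aryl ether arm

The source may hold more compounds than are shown below. What is called first, only, known or untested is meant among the compounds shown, and "the series" means these compounds.

Measured so far:
compound 1, `N#Cc1cccc(C(=O)N2CCCCC2CCOc2ccc(Cl)c(Cl)c2)c1`: 398 nM
compound 2, `O=C(c1ccccc1-c1ccccc1)N1CCCC[C@H]1CCOc1ccc(F)cc1F`: 0.159 nM

Two compounds have numbers in a functional assay on CHO cells for antagonist activity at Orexin/Hypocretin receptor type 1 (Homo sapiens), read by FLIPR; on this read-out higher numbers stand for weaker inhibition and lower numbers for stronger inhibition. Compound 1 gives 398 nM in this assay, and compound 2 gives 0.159 nM. Compound 2 therefore holds the lower of the two numbers, with compound 1 standing far above it, well beyond the scatter of repeated runs.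

Compound 3 `O=C(NC[C@@H]1CCCCN1C(=O)c1ccccc1-c1ccccc1)Nc1ccccc1` differs from compound 2 in one place: (phenylcarbamoyl)amino in place of (2,4-difluorophenoxy)methyl on a saturated chain carbon bound to a saturated ring carbon. Within the data shown here, no pair of measured compounds walks this same change, so nothing here tells how this assay answers to it; the expectation rests only on the size of the number of compound 2 and on the fact that one arm is swapped for another of the same atom count.

A clear weakening of inhibition is expected from this swap, a 190-fold higher number from compound 2 to compound 3 (2.28 log units; beyond the scatter). Compound 3 is estimated at 30 nM, with a range from 3 nM to 300 nM.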

Compound 3, inhibition constant: 1 nM
Compound 3: the middle estimate sits 30-fold (1.48 log units) above what was measured, and the stated range ends above it.
By their numbers in this assay, from the lowest: compound 2; then compound 3; then compound 1.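

On a saturated chain carbon bound to a saturated ring carbon, (phenylcarbamoyl)amino replaces (2,4-difluorophenoxy)methyl in this assay with only a modest loss, a 6.3-fold higher number from compound 2 to compound 3 (0.80 log units; beyond the scatter), so strong inhibition on this core does not require the aryl ether arm. An arm with 2 hydrogen-bond donors is accepted here in place of one with 0, although this rests on a single pair of compounds. Nothing measured here accounts for the size of this step.

From the compounds shown here alone, whether the urea or the phenyl ring of the new arm matters more remains open. Also open, going by these compounds, is how this position would respond to a primary amine, a carboxylic acid or a longer chain ending in the same urea.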